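Chlorination of the shared core: compound 3 to compound 4

A few compounds are considered here, and "the series" means these few. Any claim that something is new, unique, unknown or untested is made for them only; others in the source may bear on it.

Working notes on the series. Among the compounds with values here, in a functional assay on HCT-15 cells (Homo sapiens) for cytotoxicity, read by sulforhodamine B assay, with a stated time of 48 h (a lower number here means a stronger inhibitor of growth, a higher number a weaker inhibitor of growth), compound 3 `ClCc1ccccc1Cn1cnc2ncnc(Cl)c21` gives 2880 nM, the lowest of the three numbers so far. Compound 1 `ClCc1ccccc1Cn1cnc2c(Cl)ncnc21` gives 4670 nM in this assay, which lies within the scatter of compound 3, so the two cannot be ordered. Compound 2 `ClCc1cccc(Cn2cnc3c(Cl)nc(Cl)nc32)c1` gives 6910 nM in this assay, a number beyond the scatter of compound 3 and higher than it; compound 2 differs from compound 3 in more than one place, so its gap is not read as a single step.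

Compound 4 `ClCc1ccccc1Cn1cnc2nc(Cl)nc(Cl)c21` has not yet been measured in this assay. It differs from compound 3 by chloro in place of hydrogen on an aromatic carbon. Within the data shown here, no pair of measured compounds that differ in one place exists in this set, so nothing here shows what a second chloro on the core does to growth inhibition. Among the measured compounds shown here, the change is expected to give a step of a 1.2-fold higher number from compound 3 to compound 4 (0.08 log units; within the scatter), that is, no step clearly beyond the scatter. Compound 4 is therefore estimated at 3500 nM, with an expected range from 1200 nM to 10000 nM.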

Compound 4, concentration for total growth inhibition: 430 nM
Estimate against measurement, compound 4: 8.1-fold (0.91 log units) above; measured number outside the range, below it.
By their numbers in this assay, from the lowest: compound 4; then compounds 3, 1 and 2 (each within the scatter of the next, the first and the last beyond it).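

In this assay, within the data shown here, chloro in place of hydrogen on an aromatic carbon, between two ring nitrogen atoms, gives a 6.7-fold lower number from compound 3 to compound 4 (0.83 log units; beyond the scatter) and so provides the first single-place step. This position on the shared core therefore responds to substitution, as a single added chlorine moves growth inhibition beyond the scatter towards a stronger inhibitor. Nothing measured here bears on the origin of this step.

Whether the step is specific to chloro remains open, as no amine, methoxy or methyl group at this position appears among the compounds shown. As far as these compounds go, it is also open whether the same change would give a similar step on compound 1 or whether it depends on the arrangement of the core in compound 3.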